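The source may hold more compounds than are shown below. What is called first, only, known or untested is meant among the compounds shown, and "the series" means these compounds.

Compound 1 `CC(C)(C)c1ccc(C(=O)NCc2ccc(C(N)=O)cc2)cc1`, compound 2 `CC(C)Oc1ccc(CNC(=O)c2ccc(C(C)(C)C)cc2)cc1` and compound 3 `CC(C)(C)c1ccc(C(=O)NCc2ccc(NS(C)(=O)=O)cc2)cc1` share one core and differ only in a single group on an aromatic carbon. In an assay on HeLa cells with Bile acid receptor (Homo sapiens) as the target, read by a luciferase reporter, with a stated time of 24 h (a higher number here means that more compound is needed for the effect, a lower number that less compound is needed), compound 1 gives 3800 nM, compound 2 gives 170 nM and compound 3 gives 44 nM. Compound 3 therefore stands lowest of the three: the step of an 86-fold lower number from compound 1 to compound 3 (1.94 log units; beyond the scatter) and the step of a 3.9-fold lower number from compound 2 to compound 3 (0.59 log units; beyond the scatter) are both beyond the scatter, as is the step of a 22-fold lower number from compound 1 to compound 2 (1.35 log units; beyond the scatter). Compound 4 `CC(C)(C)c1ccc(C(=O)NCc2ccc(-c3nnn[nH]3)cc2)cc1` is the next change from compound 3: 1H-tetrazol-5-yl in place of methanesulfonamido on an aromatic carbon. The two steps that bear on it, those ending in compound 3, show that exchanging the group at this one place moves the number strongly, and that the three groups tried so far give three clearly separated results. Which way 1H-tetrazol-5-yl will fall cannot be read from these data. Compound 4 is therefore expected to show a 2.3-fold higher number from compound 3 to compound 4 (0.36 log units; beyond the scatter), with wide uncertainty. The estimate for compound 4 in this assay is 100 nM, within a range from 25 nM to 500 nM.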

Compound 4, half-maximal effective concentration: 120 nM
Estimate against measurement, compound 4: 1.2-fold (0.08 log units) below, within the range that was stated.
By their numbers in this assay, from the lowest: compound 3; then compounds 4 and 2 (each within the scatter of the next); then compound 1.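

In this assay replacing methanesulfonamido with 1H-tetrazol-5-yl gives a 2.7-fold higher number from compound 3 to compound 4 (0.44 log units; beyond the scatter) as a modest rise, so this position still tells apart two groups that match in heavy-atom count. Against isopropoxy, 1H-tetrazol-5-yl gives a 1.4-fold lower number from compound 2 to compound 4 (0.15 log units; within the scatter) and cannot be separated from it, although the two groups look very different, while against carbamoyl it gives a 32-fold lower number from compound 1 to compound 4 (1.50 log units; beyond the scatter) and so leaves carbamoyl alone, far from the other three groups. No measurement at hand explains why these groups differ as they do.

Still open, from the compounds shown here alone, is how a carboxylic acid, an amine or a longer chain at this same place would compare with these four groups. Also open, going by these compounds, is whether the same order of groups would hold if the tert-butyl group of the shared core were exchanged.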